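Changing the Sulfonyl Aryl Group: What to Expect for Compound 4

The source may hold more compounds than are shown below. What is called first, only, known or untested is meant among the compounds shown, and "the series" means these compounds.

Of the compounds shown here, three built on a shared core have been measured in an ADME assay on microsomes from liver (Mus musculus) for metabolic stability, with a stated time of 30 min, tested at 1 uM; on this read-out higher numbers stand for a more stable compound and lower numbers for a less stable compound. Compound 1 `N#C/N=C(\NCc1ccc(S(=O)(=O)c2ccccc2)cc1)Nc1cccnc1` gives 14%. Compound 3 `N#C/N=C(\NCc1ccc(S(=O)(=O)N2CC3CCC(C2)O3)cc1)Nc1cccnc1` gives 5.5%, and the step of a number 8.5 percentage points lower from compound 1 to compound 3 (within the scatter) shows that replacing the group on the sulfonyl sulfur left the read-out essentially unchanged. Compound 2 `N#C/N=C(\NCc1ccc(S(=O)(=O)c2cccc(C(F)(F)F)c2)cc1)Nc1ccncc1` stands highest of the three with 74%, beyond the scatter above both compound 1 and compound 3. Compound 2 differs from compound 1 in two places at once, so no single step accounts for its higher number.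

Compound 4 `N#C/N=C(\NCc1ccc(S(=O)(=O)c2cccc3cccnc23)cc1)Nc1ccncc1` is not yet measured. It carries quinolin-8-yl in place of 3-(trifluoromethyl)phenyl on a sulfonyl sulfur. Going by the values given here, the only measured step at the same place, from compound 1 to compound 3, was within the scatter, which suggests that a change on the sulfonyl sulfur need not move this assay much. Yet compound 2 alone carries the 3-(trifluoromethyl)phenyl group that now leaves, and its value sits far from the other two, so a decrease cannot be excluded. Compound 4 is therefore expected to fall, with an estimated step of a number 29 percentage points lower from compound 2 to compound 4 (beyond the scatter). Compound 4 is estimated at 45%, with a range from 15% to 75%.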

Compound 4, percent of the compound remaining: 11%
For compound 4 the middle estimate is 34 percentage points above the measured one; the measured number lies below the stated range.
By their numbers in this assay, from the lowest: compounds 3, 4 and 1 (each within the scatter of the next); then compound 2.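

Swapping quinolin-8-yl for 3-(trifluoromethyl)phenyl on the sulfonyl sulfur, with the rest of the molecule unchanged, gave a number 63 percentage points lower from compound 2 to compound 4 (beyond the scatter) in this assay. Going by these compounds alone, this is the first single change at this place to go beyond the scatter, so the earlier step, a number 8.5 percentage points lower from compound 1 to compound 3 (within the scatter), does not mean that the group here is unimportant for this read-out. The two groups hold the same number of heavy atoms but differ in make-up: the three fluorines leave, while a second aromatic ring, containing a nitrogen and counted as a hydrogen-bond acceptor, enters; no measurement here explains why the number fell.

From the compounds shown here alone, it remains open which of these differences matters, and whether 3-(trifluoromethyl)phenyl is unusually favourable or quinolin-8-yl unfavourable, as compound 2 and compound 1 differ in two places and offer no clean comparison with a plain phenyl group. A naphthyl group on the same sulfonyl sulfur would separate the effect of the second ring from that of its nitrogen, and a chlorophenyl group would test whether the fluorines can be replaced by another halogen.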